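Ethyl-to-chloro swap on the aryl ring of compound 2

This account rests on a few compounds, and the source may have more. Where it says the series, first, only, none or still open, it means among the compounds named here.

Measured so far in a functional assay on CCRF-CEM cells (Homo sapiens) for inhibition, read by cell counting, with a stated time of 3 days; on this read-out lower numbers stand for stronger inhibition and higher numbers for weaker inhibition:
Compound 1, `CCc1ccc(-c2nn3cc(-c4cccc(N)c4)nc3s2)cc1`, gives 22000 nM.
Compound 2, `C=C(Br)C(=O)Nc1cccc(-c2cn3nc(-c4ccc(CC)cc4)sc3n2)c1`, gives 3400 nM.
Compound 3, `C=C(Br)C(=O)Nc1cccc(-c2cn3c(-c4ccc(Cl)cc4)csc3n2)c1`, gives 2200 nM.

Compound 2 holds the second highest of the three numbers; compound 1 sits higher, beyond the scatter, while compound 3 lies within the scatter of compound 2. Going by the values given here, the only measured step, a 6.5-fold lower number from compound 1 to compound 2 (0.81 log units; beyond the scatter), concerns the acyl group on the ring nitrogen and does not touch the position now changed.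

Compound 4, `C=C(Br)C(=O)Nc1cccc(-c2cn3nc(-c4ccc(Cl)cc4)sc3n2)c1`, differs from compound 2 by chloro in place of ethyl on an aromatic carbon. Among the compounds with values here, no measured pair covers this swap; compound 3 carries chloro on another arrangement of the shared core and its number is within the scatter of compound 2. Hence no step beyond the scatter is expected: compound 4 is estimated at 2800 nM (range 1000 nM to 8000 nM), a change of a 1.2-fold lower number from compound 2 to compound 4 (0.08 log units; within the scatter).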

Compound 4, half-maximal inhibitory concentration: 3200 nM
Compound 4: middle estimate off by 1.1-fold (0.06 log units), on the low side; the measured number falls inside the stated range.
By their numbers in this assay, from the lowest: compounds 3, 4 and 2 (each within the scatter of the next); then compound 1.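

In this assay, going by these compounds alone, chloro in place of ethyl on the aromatic carbon para to a large group gives a 1.1-fold lower number from compound 2 to compound 4 (0.03 log units; within the scatter) as the first direct reading at this position. With the (1-bromoethenyl)carbonyl group kept on the nitrogen, the 4-ethylphenyl and 4-chlorophenyl compounds cannot be told apart on this read-out. No evidence on hand bears on this result.

On these data alone, whether an amine, a carboxylic acid or a longer chain at this position would move the number beyond the scatter remains open. Also open, as far as these compounds go, is whether chloro and ethyl stay equivalent on the free aromatic amine.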